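A few compounds are considered here, and "the series" means these few. Any claim that something is new, unique, unknown or untested is made for them only; others in the source may bear on it.

In a functional assay on DU-145 cells (Homo sapiens) for inhibition, read by MTT assay, with stated times of 18 h and 4 h (on this read-out lower numbers stand for stronger inhibition and higher numbers for weaker inhibition), compound 1 (`CCCCCCCCOP(=O)(O)OCCSC(=S)N1CCCC1`) gives 47100 nM and compound 2 (`CCCCCCCCCCOP(=O)(O)OCCSC(=S)N1CCCC1`) gives 46100 nM, so these two stand level within the scatter. Compound 3 (`CCCOP(=O)(O)OCCSC(=S)N1CCCC1`) departs from compound 2 as follows: hydrogen in place of heptyl on a saturated chain carbon, three bonds along the chain from an oxygen on an unsaturated carbon. Going by the values given here, only one measured step bears on this change: a 1.0-fold lower number from compound 1 to compound 2 (0.01 log units; within the scatter), ethyl in place of hydrogen on a saturated chain carbon, and it lies within the scatter. Among the compounds with values here, that flat step covers a much smaller change than hydrogen in place of heptyl, and no measured compound shows what happens on removing so much of the chain. A modest move to a higher number is therefore expected in this assay, with wide uncertainty, and no change at all remains possible. The expected size is a 1.7-fold higher number from compound 2 to compound 3 (0.24 log units; within the scatter). For compound 3 the estimate is 80000 nM, with an expected range of 35000 nM to 220000 nM.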

Compound 3, half-maximal inhibitory concentration: > 100000 nM
Compound 3 ended at the assay's limit (the forecaster's own chance of this, stated with the estimate: 25%); middle value at least 1.2-fold (0.09 log units) from the limit.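

Unlike the flat pair of longer chains, this position does respond to change once the chain is cut far enough: hydrogen in place of heptyl gives an at least 2.1-fold higher number from compound 2 to compound 3 (0.33 log units; beyond the scatter), and hydrogen in place of pentyl gives an at least 2.1-fold higher number from compound 1 to compound 3 (0.32 log units; beyond the scatter). In this assay compound 3 gives > 100000 nM, which is a limit and not a number. Both steps therefore fix only a minimum size, and the true distance of compound 3 from compound 1 and compound 2 stays unknown: the limit of > 100000 nM in this assay, at which 1 of the 3 values shown sits.

Open, from the compounds shown here alone, is where along the chain, between the length in compound 3 and that in compound 1, the number begins to rise. Also open, going by these compounds, is whether a longer chain, or a chain ending in an amine or a carboxylic acid, would stay level with compound 1 and compound 2.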